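This account rests on a few compounds, and the source may have more. Where it says the series, first, only, none or still open, it means among the compounds named here.

Working notes on the anilino series sharing one core.

The series is read in a functional assay on MGC-803 cells (Homo sapiens) for inhibition, read by sulforhodamine B assay; a higher number here means a weaker inhibitor, a lower number a stronger inhibitor. Compound 1 `COc1cccc(NC2=CC(=O)c3c(nc4n3[C@H]3OC[C@@H](O)[C@H]3OC4)C2=O)c1` gives 1790 nM. Compound 2 `COc1cccc(NC2=CC(=O)c3nc4n(c3C2=O)[C@H]2OC[C@@H](O)[C@H]2OC4)c1` gives 1780 nM, and compound 3 `CCc1ccc(NC2=CC(=O)c3nc4n(c3C2=O)[C@H]2OC[C@@H](O)[C@H]2OC4)cc1` gives 1290 nM. Compound 1 carries the top number of the three, yet the distances to compound 2 and to compound 3 both fall within the usual scatter, so the three compounds cannot be separated on the figures at hand; compound 1 sits with the other two rather than apart from them.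

Going by the values given here, the one measured step that changes the aryl group on the amine nitrogen is a 1.4-fold lower number from compound 2 to compound 3 (0.14 log units; within the scatter). It shows that exchanging the anilino aryl for a different aryl of similar size left this assay essentially untouched.

The step from compound 1 to compound 4 `O=C1C(Nc2ccc(C(F)(F)F)cc2)=CC(=O)c2c1nc1n2[C@H]2OC[C@@H](O)[C@H]2OC1` is of the same kind: 4-(trifluoromethyl)phenyl in place of 3-methoxyphenyl on an amine nitrogen. Among the compounds with values here, the only aryl-for-aryl precedent in the set is the step from compound 2 to compound 3, which stayed within the scatter, so no change beyond the scatter is expected here either; the direction is left open.

Compound 4 is therefore estimated at 1500 nM in this assay, with a range of 600 nM to 4000 nM, which corresponds to an expected step of a 1.2-fold lower number from compound 1 to compound 4 (0.08 log units; within the scatter).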

Compound 4, half-maximal inhibitory concentration: 1860 nM
Beside the measured number, compound 4's estimate is 1.2-fold (0.09 log units) below it, within the range that was stated.
By their numbers in this assay, from the lowest: compounds 3, 2, 1 and 4 (each within the scatter of the next).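

In this assay, putting 4-(trifluoromethyl)phenyl in place of 3-methoxyphenyl on the amine nitrogen gives a 1.0-fold higher number from compound 1 to compound 4 (0.02 log units; within the scatter), so this exchange leaves no readable mark on the number. Together with a 1.4-fold lower number from compound 2 to compound 3 (0.14 log units; within the scatter), this gives a second aryl-for-aryl exchange on an amine nitrogen that stays within the scatter, now on a pair whose entering group carries fluorine in place of the oxygen of the leaving group and has more heavy atoms. Across the aryl groups shown, the position therefore gives no separation in this assay, although only two single exchanges support that reading, and no measurement at hand ties the outcome to any property of either group.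

All the groups shown on this nitrogen are substituted phenyl rings, so the result says nothing about how the position responds to a basic amine such as a dimethylaminomethyl group or to a carboxylic acid on the ring. It also leaves open whether replacing the aryl ring with a longer alkyl chain or an unsubstituted benzyl group would move the number beyond the scatter.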